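Carbamate in place of ethyl on the core of compound 1

The source may hold more compounds than are shown below. What is called first, only, known or untested is meant among the compounds shown, and "the series" means these compounds.

Measured compounds:
compound 1 `CCOc1cc(=O)n(CCCO)c2c1CC(CC=C(C)C)C(C)(C)C2` — 66.5%
compound 2 `CC(C)=CCC1Cc2c(OCCCNS(=O)(=O)c3ccc(Br)cc3)cc(=O)n(CCCO)c2CC1(C)C` — 19.5%
compound 3 `COc1ccc(C(=O)NCCCOc2cc(=O)n(CCCO)c3c2CC(CC=C(C)C)C(C)(C)C3)cc1` — 55.5%

All three share one core and were tested in a functional assay on PANC-1 cells (Homo sapiens) for inhibition, read by MTT assay, with a stated time of 24 h, tested at 10 uM; a lower number here means less inhibition, a higher number more inhibition at the concentration tested (going by the name of the read-out). Compound 1 carries an ethyl on the aromatic oxygen and gives the highest number of the three. Compound 3, with a benzamide-bearing chain on that oxygen, sits closest, and compound 2, with a sulfonamide-bearing chain, sits furthest away: a number 11 percentage points lower from compound 1 to compound 3 (beyond the scatter) and a number 47 percentage points lower from compound 1 to compound 2 (beyond the scatter). Between those two larger groups the step is a number 36 percentage points higher from compound 2 to compound 3 (beyond the scatter).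

Compound 4 `CC(C)=CCC1Cc2c(OC(=O)Nc3ccccc3F)cc(=O)n(CCCO)c2CC1(C)C` has not yet been measured. It differs from compound 1 by (2-fluorophenyl)carbamoyl in place of ethyl on an oxygen on an aromatic ring. Within the data shown here, this change attaches an aromatic ring through a carbamate directly at the oxygen rather than through a longer chain, so no measured step matches it exactly. Among the measured compounds shown here, still, both measured steps that enlarge the group on this oxygen lowered inhibition, and the one with a carbonyl-bearing group, a number 11 percentage points lower from compound 1 to compound 3 (beyond the scatter), did so only modestly. Compound 4 is therefore expected to fall below compound 1 by a modest to moderate step, a number 18.5 percentage points lower from compound 1 to compound 4 (beyond the scatter). The estimate for compound 4 is 48%, within a range from 25% to 66%.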

Compound 4, a percentage reported as inhibition, at one concentration (the size of the read-out at that concentration, not a potency): 52.3%
For compound 4 the middle estimate is 4.3 percentage points below the measured one; the range from low to high includes it.
By their numbers in this assay, from the lowest: compound 2; then compounds 4 and 3 (each within the scatter of the next); then compound 1.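

In this assay, the step from ethyl to (2-fluorophenyl)carbamoyl on this oxygen is a number 14.2 percentage points lower from compound 1 to compound 4 (beyond the scatter), which shows that a third kind of larger group also falls short of the small ethyl, so that all three enlarged groups shown lie under compound 1 with no exception. It also shows that an aromatic ring can be attached through a carbamate directly at this oxygen, without a longer chain, and still keep much of the read-out: compound 4 gives 52.3% and compound 3 gives 55.5%, two values within the scatter of each other, so this assay does not separate these two groups. Nothing available explains the drop seen with either group at this oxygen.

The compounds shown leave open whether the fluorine contributes anything, since an unsubstituted phenyl carbamate is absent from this set, and whether a urea in place of the carbamate would read the same. They also leave open how a group smaller than ethyl, such as methyl, would compare, and each number here comes from one concentration, so none of them gives a potency.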